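Naphthalen-1-yl on the sulfonamide nitrogen of compound 2

This account rests on a few compounds, and the source may have more. Where it says the series, first, only, none or still open, it means among the compounds named here.

Measured so far in an ADME assay on Vero cells (Chlorocebus sabaeus) for antiproliferative activity, read by MTT assay, with a stated time of 72 h; on this read-out lower numbers stand for stronger inhibition and higher numbers for weaker inhibition (both values are limits)
Compound 1 `Cc1cccc(N(C)S(=O)(=O)C2CC3OC2C(c2ccc(NC(=O)CCCCCCC(=O)O)cc2)=C3c2ccc(O)cc2)c1` gives > 100000 nM 
Compound 2 `CN(c1ccccc1Cl)S(=O)(=O)C1CC2OC1C(c1ccc(NC(=O)CCCCCCC(=O)O)cc1)=C2c1ccc(O)cc1` gives > 100000 nM 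

In this assay compound 2 gives > 100000 nM and this is a limit, not a number. Compound 1 also gives only a limit (> 100000 nM). The whole record is thus the limit of > 100000 nM in this assay, at which 2 of the 2 values shown sit, and compound 2 cannot be ranked.

Compound 3 `CN(c1cccc2ccccc12)S(=O)(=O)C1CC2OC1C(c1ccc(NC(=O)CCCCCCC(=O)O)cc1)=C2c1ccc(O)cc1` differs from compound 2 by naphthalen-1-yl in place of 2-chlorophenyl on a sulfonamide nitrogen with naphthalen-1-yl in place of 2-chlorophenyl on a sulfonamide nitrogen. Among the measured compounds shown here, one measured step bears on this, at that same nitrogen: a step that the two limits leave unreadable from compound 1 to compound 2 with 2-chlorophenyl in place of 3-methylphenyl. Its size cannot be read, so it offers no direction, and compound 3 is expected to remain at the limit in this assay. The expected change is a number no higher from compound 2 to compound 3 (the limit leaves the size open) and no more than the scatter. Compound 3 is estimated at 100000 nM with a range from 40000 nM to 250000 nM.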

Compound 3, half-maximal inhibitory concentration: > 100000 nM
Compound 3: a limit, no number; the forecaster's own chance of this, stated with the estimate: 85%; the middle value lies on the limit itself.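

No step among compound 1, compound 2 and compound 3 can be read in this assay, since all three values are limits and not numbers: the limit of > 100000 nM in this assay, at which 3 of the 3 values shown sit.

The compounds shown leave open how far each one lies beyond that limit, and whether the 3-methylphenyl, 2-chlorophenyl and naphthalen-1-yl groups on the sulfonamide nitrogen differ at all in this read-out.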